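Removing the Methyl Group: Expected Lipophilicity of Compound 4

The source may report more compounds than this note shows. Statements on the series, on what has been measured and on what is new or still open speak of the compounds shown alone.

Of the compounds shown here, three sharing one core have been measured in a physicochemical assay for lipophilicity, in phosphate buffer, measured as octanol-water partition, with a stated time of 24 h; a lower number here means a more polar compound, a higher number a more lipophilic compound. Compound 1 `O=C(N/N=C\c1ccc(Oc2ccc3ccccc3c2)cc1)c1ccncc1` gives 4.52, compound 2 `O=C(N/N=C\c1ccc(Oc2ccc(Br)cc2)cc1)c1ccncc1` gives 4.03, and compound 3 `Cc1ccc(Oc2ccc(/C=N\NC(=O)c3ccncc3)cc2)cc1` gives 3.65. Compound 3 thus stands lowest of the three, with compound 2 nearest and compound 1 furthest away. Among the compounds with values here, the one measured step between neighbours, a number 0.38 log units lower from compound 2 to compound 3 (beyond the scatter), shows that swapping the group at this position moves the number modestly but beyond the scatter.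

Compound 4 `O=C(N/N=C\c1ccc(Oc2ccccc2)cc1)c1ccncc1` is not yet measured. It differs from compound 3 by hydrogen in place of methyl on an aromatic carbon. Within the data shown here, no measured pair shows exactly this change, so the expectation rests on the shared core and on the modest size of the step from compound 2 to compound 3. Compound 4 is expected to give a somewhat lower number in this assay than compound 3, an estimated step of a number 0.50 log units lower from compound 3 to compound 4 (beyond the scatter). The value expected for compound 4 is 3.15, within a range from 2.7 to 3.6.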

Compound 4, partition coefficient: 3.37
For compound 4 the middle estimate is 0.22 log units below the measured one; measured number inside the range.
By their numbers in this assay, from the lowest: compounds 4 and 3 (each within the scatter of the next); then compound 2; then compound 1.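

At this position, on an aromatic carbon para to a large group, hydrogen in place of methyl gives a step that this assay cannot separate from the usual scatter (a number 0.28 log units lower from compound 3 to compound 4 (within the scatter)). Hydrogen in place of bromo does give a readable step (a number 0.66 log units lower from compound 2 to compound 4 (beyond the scatter)), so among these three groups, bromo stands clear of hydrogen, while methyl does not. Nothing available explains either step.

The compounds shown cover only hydrogen, methyl and bromo at this position, so it remains open how an amine, a carboxylic acid or a longer chain would read there. As far as these compounds go, it also remains open whether methyl or bromo on another carbon of the same ring would give steps of similar size.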